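This account rests on a few compounds, and the source may have more. Where it says the series, first, only, none or still open, it means among the compounds named here.

Compounds measured so far:

- compound 1, `CN1CCC[C@H]1[C@@H]1COc2ccc([N+](=O)[O-])cc2O1`: 4500 nM
- compound 2, `CN1CCC[C@H]1[C@H]1COc2ccc([N+](=O)[O-])cc2O1`: 2100 nM
- compound 3, `CN1CCC[C@H]1[C@@H]1COc2cc(-c3ccccc3)ccc2O1`: 5400 nM

These numbers come from an assay on membranes from HEK293 cells for displacement of a labelled ligand from Neuronal acetylcholine receptor; alpha3/beta4 (Homo sapiens), with a stated time of 5 min; a lower number here means a stronger inhibitor, a higher number a weaker inhibitor. Among the three, compound 2 stands lowest: compound 1 lies a 2.1-fold lower number from compound 1 to compound 2 (0.33 log units; beyond the scatter) away, and the only change there is the drawn configuration of one ring carbon (the fact that compounds 1 and 2 differ only in the configuration as drawn). Compound 3, with a phenyl group in place of the nitro group and the configuration of compound 1, gives a somewhat higher number than compound 2.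

The next compound, compound 4, `CN(C)c1ccc2c(c1)O[C@@H]([C@@H]1CCCN1C)CO2`, differs from compound 2 by dimethylamino in place of nitro on an aromatic carbon. Within the data shown here, no measured step changes this group, so there is no direct guide. Compound 4 is therefore expected to stay close to compound 2, with a step of a 1.2-fold higher number from compound 2 to compound 4 (0.08 log units; within the scatter), estimated at 2500 nM within 800 nM to 8000 nM.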

Compound 4, inhibition constant: 25000 nM
Beside the measured number, compound 4's estimate is 10-fold (1.00 log units) below it; measured number above the stated range.
By their numbers in this assay, from the lowest: compound 2; then compounds 1 and 3 (each within the scatter of the next); then compound 4.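

Among these compounds, replacing nitro with dimethylamino on this aromatic carbon gives a 12-fold higher number from compound 2 to compound 4 (1.08 log units; beyond the scatter), a large step and far bigger than the one seen for the change in configuration. The two groups have the same number of heavy atoms, so that count does not separate them, yet the number still moves strongly with the group at this position. Nothing measured here explains why this change has such an effect.

As far as these compounds go, it remains open whether a nitrile or a plain amino group on this carbon would give a number nearer that of compound 2 or compound 4. From the compounds shown here alone, it is also open whether the same replacement would give a step of similar size on compound 1.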